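The compounds below may be only part of what the source reports. "The series", "measured", "known", "first", "only" and "open" are said of these compounds alone.

Compound 2 `COc1ccc(Cl)cc1N(CC(=O)N1CCCCC1)S(=O)(=O)c1ccccc1` gives 14500 nM in a functional assay on SH-SY5Y cells (Homo sapiens), read by MTT assay, with a stated time of 24 h (a lower number here means that less compound is needed, a higher number that more compound is needed for the effect), the only numerical value among those shown. Compound 1 `COc1ccc(Cl)cc1N(CC(=O)N1CCc2ccccc21)S(=O)(=O)c1ccccc1` gives > 20000 nM in this assay, which is a limit of the assay rather than a number. The step of an at least 1.3-fold lower number from compound 1 to compound 2 (0.13 log units; that floor lies within the scatter) is the sole measured one, and it rests on (the limit of > 20000 nM in this assay, at which 1 of the 2 values shown sits). Compound 3 `COc1ccc(Cl)cc1NC(=O)CN(c1cc(Cl)ccc1OC)S(=O)(=O)c1ccccc1` differs from compound 2 by (5-chloro-2-methoxyphenyl)amino in place of piperidin-1-yl on a carbonyl carbon. For the measured compounds named here, the single measured step on the same carbonyl carbon was small, so compound 3 is expected to show a step of a 1.0-fold higher number from compound 2 to compound 3 (0.01 log units; within the scatter) that stays within the scatter. Compound 3 is therefore estimated at 15000 nM, within 5000 nM to 40000 nM.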

Compound 3, half-maximal effective concentration: > 20000 nM
Compound 3: only a limit was reported; the forecaster's own chance of this, stated with the estimate: 40%; middle value at least 1.3-fold (0.12 log units) away from the limit.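

In this assay the change to (5-chloro-2-methoxyphenyl)amino on the carbonyl carbon gives an at least 1.3-fold higher number from compound 2 to compound 3 (0.13 log units; that floor lies within the scatter) and leaves compound 3 with a limit rather than a number. Piperidin-1-yl thus remains the only group shown at this place with a readable number, while the step from compound 1 to compound 3 cannot be read, as both values are limits. Every reading at this place is bounded by that limit: the limit of > 20000 nM in this assay, at which 2 of the 3 values shown sit.

Going by these compounds, how far compound 3 actually lies from compound 2 stays open. So does whether a smaller ring such as pyrrolidin-1-yl or morpholin-4-yl on this carbonyl carbon would give a number.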